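Acetyl for methoxy on the arylsulfonamide series

A few compounds are considered here, and "the series" means these few. Any claim that something is new, unique, unknown or untested is made for them only; others in the source may bear on it.

Measured so far:
compound 1 `C[C@@H]1CN(c2cc(NS(=O)(=O)c3ccc(-c4ccccn4)s3)ccc2C#N)C[C@H](C)N1` — 631 nM in a functional assay for agonist activity at growth hormone secretagogue receptor type 1 (Homo sapiens), read by FLIPR; a higher number here means that more compound is needed for the effect, a lower number that less compound is needed
compound 2 `COc1ccc(N2C[C@@H](C)N[C@@H](C)C2)cc1NS(=O)(=O)c1ccc(-c2ccccn2)s1` — 10 nM in this assay

Compound 2 holds the lowest of the two numbers; the gap to compound 1 is beyond the scatter. Compound 3 `CC(=O)c1ccc(N2C[C@@H](C)N[C@@H](C)C2)cc1NS(=O)(=O)c1ccc(-c2ccccn2)s1` is not yet measured. It differs from compound 2 in one place: acetyl in place of methoxy on an aromatic carbon. Going by the values given here, no measured pair shows this change, so the step of a 2.5-fold higher number from compound 2 to compound 3 (0.40 log units; beyond the scatter) is expected to be small and, if anything, toward a higher number. Compound 3 is estimated at 25 nM, within 6 nM to 100 nM.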

Compound 3, half-maximal effective concentration: 39.8 nM
Compound 3: the middle estimate sits 1.6-fold (0.20 log units) below what was measured; the measured number falls inside the stated range.
By their numbers in this assay, from the lowest: compound 2; then compound 3; then compound 1.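

In this assay, acetyl in place of methoxy on this aromatic carbon, para to a 3,5-dimethylpiperazin-1-yl group, gives a 4.0-fold higher number from compound 2 to compound 3 (0.60 log units; beyond the scatter). Going by these compounds alone, this is the first direct reading at this position: the change costs a modest but real step, and compound 3 keeps agonist activity. Nothing available explains the step.

On these data alone, it remains open how an ethoxy group, a primary amide or a carboxylic acid on the same carbon would read. Whether the step carries over to other sulfonamide partners is also unknown.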